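A few compounds are considered here, and "the series" means these few. Any claim that something is new, unique, unknown or untested is made for them only; others in the source may bear on it.

Measured compounds in a functional assay on PBMC cells (Homo sapiens) for inhibition; a higher number here means a weaker inhibitor, a lower number a stronger inhibitor:
- compound 1, `CSCC[C@H](N)C(=O)NS(=O)(=O)OC[C@H]1OC[C@@H](n2cnc3c(N)ncnc32)[C@H](O)[C@@H]1O`, gives 5200 nM
- compound 2, `CSCC[C@H](N)C(=O)NS(=O)(=O)OC[C@H]1OC[C@@H](n2cnc3c(N)ncnc32)C[C@@H]1O`, gives 5500 nM
- compound 3, `C[C@H](N)C(=O)NS(=O)(=O)OC[C@H]1OC[C@@H](n2cnc3c(N)ncnc32)[C@H](O)[C@@H]1O`, gives 300 nM

Compound 4, `C[C@H](N)C(=O)NS(=O)(=O)OC[C@H]1OC[C@@H](n2cnc3c(N)ncnc32)C[C@@H]1O`, has not yet been measured.

Compounds 1 and 2 share a core and differ in one place: hydrogen in place of hydroxy on a saturated ring carbon. That change gave a 1.1-fold higher number from compound 1 to compound 2 (0.02 log units; within the scatter), so in this assay the two compounds cannot be told apart.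

Compound 3 sits on a different core from compound 1; the difference between the cores is hydrogen in place of (methylsulfanyl)methyl on a saturated chain carbon, two bonds along the chain from an amine nitrogen and a carbonyl carbon. That change gave a 17-fold lower number from compound 1 to compound 3 (1.24 log units; beyond the scatter), which is the only large movement among the three measured compounds and leaves compound 3 with the lowest number of the three.

Compound 4 is built from compound 3 by the same change that turned compound 1 into compound 2: hydrogen in place of hydroxy on a saturated ring carbon. The place of the change is described in identical terms on both cores, so it is the same change, made once on each core.

On the core of compound 1 this change did not move the number beyond the scatter, as a 1.1-fold higher number from compound 1 to compound 2 (0.02 log units; within the scatter) shows. The expectation for compound 4 is therefore a step of about a 1.1-fold higher number from compound 3 to compound 4 (0.04 log units; within the scatter), resting on that earlier step and on compound 3 as the starting point. Compound 4 is thus estimated at 330 nM, with the likely range running from 150 nM to 700 nM.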

Compound 4, half-maximal inhibitory concentration: 5500 nM
Beside the measured number, compound 4's estimate is 17-fold (1.22 log units) below it; the measured number lies above the stated range.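

In this assay, taking away the hydroxy group on the saturated ring carbon gave an 18-fold higher number from compound 3 to compound 4 (1.26 log units; beyond the scatter), so the near-silent result of this change on the core of compound 1 does not carry over to the core of compound 3: the same change on two cores in this assay, a 1.1-fold higher number (0.02 log units; within the scatter) from compound 1 to compound 2 and an 18-fold higher number (1.26 log units; beyond the scatter) from compound 3 to compound 4, 17-fold (1.24 log units) apart, beyond the scatter of two such steps. The other change, hydrogen in place of (methylsulfanyl)methyl, gave no change at the digits printed from compound 2 to compound 4 (within the scatter) on the cores without the hydroxy group, although it had a large effect where the hydroxy group was present: the same change on two cores in this assay, a 17-fold lower number (1.24 log units; beyond the scatter) from compound 1 to compound 3 and no change at the digits printed (within the scatter) from compound 2 to compound 4, 17-fold (1.24 log units) apart, beyond the scatter of two such steps. The two changes therefore do not add up independently in this series: compound 3, which has the hydroxy group and lacks the (methylsulfanyl)methyl, stands apart from both of its single-change neighbours, compound 1 and compound 4, but this one set of four compounds does not show why this happens or whether it holds beyond them.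

The compounds shown leave open whether a different group on that ring carbon, such as fluorine or an amine, would behave like the hydroxy group or like hydrogen. They also leave open how a side chain of intermediate length, such as an ethyl group, would respond to the same change.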